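The source may report more compounds than this note shows. Statements on the series, on what has been measured and on what is new or still open speak of the compounds shown alone.

Measured so far:
- compound 1, `COc1ccc(-c2nc3cc(F)ccc3s2)cc1Cl`, gives 7050 nM in a functional assay on KM12 cells (Homo sapiens) for antiproliferative activity; on this read-out higher numbers stand for weaker inhibition of growth and lower numbers for stronger inhibition of growth
- compound 2, `COc1ccc(-c2nc3cc(F)ccc3s2)cc1Br`, gives 6700 nM in this assay
- compound 3, `COc1ccc(-c2nc3cc(Cl)ccc3s2)cc1OC`, gives 12400 nM in this assay

Compound 2 differs from compound 1 by one change, (bromo in place of chloro on an aromatic carbon). This change made the step of a 1.1-fold lower number from compound 1 to compound 2 (0.02 log units; within the scatter), so the two numbers sit inside the usual run-to-run variation. Compound 3 and compound 1 have different cores; how the two cores differ is not broken down here. Compound 3 has the highest number of the three, but its gaps to compound 1 and compound 2 are also within the scatter, so no order among them can be read off.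

Compound 4, `COc1ccc(-c2nc3cc(Br)ccc3s2)cc1OC`, is not yet measured. It differs from compound 3 by bromo in place of chloro on an aromatic carbon. For the measured compounds named here, this is the same kind of change as the one from compound 1 to compound 2, but the place differs: in compound 1 it sits ortho to a methoxy group and meta to a large group, in compound 3 it sits meta to a fused ring and para to a fused ring. Because the earlier step of a 1.1-fold lower number from compound 1 to compound 2 (0.02 log units; within the scatter) was small, the step from compound 3 to compound 4 is expected to be about a 1.1-fold lower number from compound 3 to compound 4 (0.03 log units; within the scatter) as well. Compound 4 is therefore estimated at 11500 nM in this assay, with a likely range from 5500 nM to 24000 nM.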

Compound 4, concentration for 50% growth inhibition: 65200 nM
Estimate against measurement, compound 4: 5.7-fold (0.75 log units) below; measured number above the stated range.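

In this assay, putting bromo in place of chloro gave a 5.3-fold higher number from compound 3 to compound 4 (0.72 log units; beyond the scatter), so compound 4 inhibits growth more weakly than compound 3, a modest step. Set beside the earlier step, the result shows that this change does not carry over unaltered from one core to the other: the same change on two cores in this assay, a 1.1-fold lower number (0.02 log units; within the scatter) from compound 1 to compound 2 and a 5.3-fold higher number (0.72 log units; beyond the scatter) from compound 3 to compound 4, 5.5-fold (0.74 log units) apart, beyond the scatter of two such steps. It does not show what makes the two steps differ, since the two pairs have different cores and the change sits in a different place on each, and a single pair per core cannot separate those two differences.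

The compounds shown leave open whether the same swap made at the other core's matching place would give a similar step, which would help to tell the effect of the place from that of the core. They also leave open how an amine or a carboxylic acid would compare with chloro and bromo at the place these two halogens occupy in compound 3 and compound 4.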